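The source may hold more compounds than are shown below. What is called first, only, known or untested is meant among the compounds shown, and "the series" means these compounds.

Compound 1 `N/N=C1\C(=O)Nc2ccc(S(=O)(=O)N3CCOCC3)cc21` gives 46800 nM in a functional assay on MCF7 cells (Homo sapiens) for cytotoxicity, read by sulforhodamine B assay, with a stated time of 24 h; a lower number here means a stronger inhibitor, a higher number a weaker inhibitor.
Compound 2 `O=C1Nc2ccc(S(=O)(=O)N3CCOCC3)cc2/C1=N/NC(=O)c1ccccc1` gives 414000 nM in this assay.

Compound 2 stands highest of the two numbers in this assay, with compound 1 the nearer and lower. Compound 3 `O=C1Nc2ccc(S(=O)(=O)N3CCOCC3)cc2/C1=N/NS(=O)(=O)c1ccccc1` differs from compound 2 by phenylsulfonyl in place of benzoyl on an amine nitrogen. Of the measured steps only an 8.8-fold higher number from compound 1 to compound 2 (0.95 log units; beyond the scatter) bears on this change, and it concerns a different replacement on the same nitrogen, so it offers little direct guidance. With nothing measured for this exchange, the account expects a 1.0-fold lower number from compound 2 to compound 3 (0.01 log units; within the scatter), a step staying within the scatter, and estimates compound 3 at 400000 nM (range 130000 nM to 1200000 nM).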

Compound 3, half-maximal inhibitory concentration: 25300 nM
Compound 3: middle estimate off by 16-fold (1.20 log units), on the high side; the measured number lies below the stated range.
By their numbers in this assay, from the lowest: compounds 3 and 1 (each within the scatter of the next); then compound 2.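

In this assay, exchanging benzoyl for phenylsulfonyl on the amine nitrogen gives a 16-fold lower number from compound 2 to compound 3 (1.21 log units; beyond the scatter), so carrying a phenyl ring at this place does not by itself set the number; the linking group matters. Set against hydrogen on the same nitrogen, phenylsulfonyl gives a 1.8-fold lower number from compound 1 to compound 3 (0.27 log units; within the scatter), and the two cannot be told apart here. Nothing available explains why the two larger groups part so widely. From the compounds shown here alone, whether this holds for a methylsulfonyl group, or for a phenylsulfonyl ring bearing a methoxy or chloro substituent, remains open.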